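A few compounds are considered here, and "the series" means these few. Any claim that something is new, unique, unknown or untested is made for them only; others in the source may bear on it.

Working notes on the coumarin-free description: all three measured compounds share the core of compound 1 `Cc1c(C)c2ccc(OC3CCN(C)CC3)cc2oc1=O` and differ only in the group on the saturated chain carbon bound to the amine nitrogen in the ring. In an assay for inhibition of Amine oxidase [flavin-containing] B (Homo sapiens), read by fluorescence, using microsomes, with stated times of 20 min and 30 min (on this read-out higher numbers stand for weaker inhibition and lower numbers for stronger inhibition), compound 1 gives 274 nM. Compound 2 `CCCCN1CCC(Oc2ccc3c(C)c(C)c(=O)oc3c2)CC1` gives 1410 nM in this assay, the highest number of the three; the step of a 5.1-fold higher number from compound 1 to compound 2 (0.71 log units; beyond the scatter) lies beyond the scatter. Compound 3 `Cc1c(C)c2ccc(OC3CCN(Cc4cccc(Cl)c4)CC3)cc2oc1=O` gives 285 nM in this assay; a 1.0-fold higher number from compound 1 to compound 3 (0.02 log units; within the scatter) stays within the scatter, whereas a 4.9-fold lower number from compound 2 to compound 3 (0.69 log units; beyond the scatter) lies beyond it.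

Compound 4 `Cc1c(C)c2ccc(OC3CCN(Cc4ccc(C#N)cc4)CC3)cc2oc1=O` is not yet measured. Relative to compound 2 the change is 4-cyanophenyl in place of propyl on a saturated chain carbon bound to an amine nitrogen in a ring. The step that bears most directly on it is a 4.9-fold lower number from compound 2 to compound 3 (0.69 log units; beyond the scatter), where a substituted phenyl replaced the same propyl at the same place and the number fell by a modest amount. a 5.1-fold higher number from compound 1 to compound 2 (0.71 log units; beyond the scatter) points the same way, in that propyl at this place raised the number relative to hydrogen. For the measured compounds named here, no measured pair shows how a 4-cyanophenyl compares with a 3-chlorophenyl here, so the aryl case rests on a single example.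

A modest fall in this assay is therefore expected for compound 4, a 4.4-fold lower number from compound 2 to compound 4 (0.64 log units; beyond the scatter). Compound 4 is estimated at 320 nM, with a range of 120 nM to 900 nM.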

Compound 4, half-maximal inhibitory concentration: 656 nM
Beside the measured number, compound 4's estimate is 2.1-fold (0.31 log units) below it, within the range that was stated.
By their numbers in this assay, from the lowest: compounds 1 and 3 (each within the scatter of the next); then compound 4; then compound 2.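

In this assay, the aryl groups at this place do not behave alike: a 2.3-fold higher number from compound 3 to compound 4 (0.36 log units; beyond the scatter), so the lower number of compound 3 does not carry over unchanged to 4-cyanophenyl. Replacing propyl with 4-cyanophenyl still lowers the number, but a 2.1-fold lower number from compound 2 to compound 4 (0.33 log units; beyond the scatter) is a smaller step than a 4.9-fold lower number from compound 2 to compound 3 (0.69 log units; beyond the scatter), and butyl to 4-cyanobenzyl therefore recovers only part of what 3-chlorophenyl recovers. Hydrogen and 3-chlorophenyl remain within the scatter of each other, whereas a 2.4-fold higher number from compound 1 to compound 4 (0.38 log units; beyond the scatter), which shows that an aryl group at this place is not neutral in every case and that the outcome depends on the aryl group itself.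

No available data explain why these two aryl groups differ. The 3-chlorophenyl and 4-cyanophenyl groups differ in both the substituent and its ring placement, so the two effects cannot be separated here, and the compounds shown also leave open how an unsubstituted phenyl, a carboxylic acid on the phenyl ring or a longer chain such as hexyl would read at this place.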